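Dropping the Nitro Group from Compound 3

A few compounds are considered here, and "the series" means these few. Any claim that something is new, unique, unknown or untested is made for them only; others in the source may bear on it.

Measured so far in a functional assay on GC-1 cells (Mus musculus) for cytotoxicity, read by MTT assay, with a stated time of 72 h; on this read-out lower numbers stand for stronger inhibition and higher numbers for weaker inhibition:
- compound 1 `Nc1nc(Nc2ccc(S(N)(=O)=O)cc2)sc1C(=O)c1cccnc1`: 20000 nM
- compound 2 `Nc1nc(Nc2ccc(S(N)(=O)=O)cc2)sc1C(=O)c1ccccc1[N+](=O)[O-]`: 20000 nM
- compound 3 `Nc1nc(Nc2ccc(S(N)(=O)=O)cc2)sc1C(=O)c1cccc([N+](=O)[O-])c1`: 22000 nM

The three compounds share one core and differ only in the group on the carbonyl carbon. Compound 3, with its 3-nitrophenyl group, stands level with the other two, as all of its gaps lie within the scatter.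

The next compound is compound 4 `Nc1nc(Nc2ccc(S(N)(=O)=O)cc2)sc1C(=O)c1ccccc1`. It carries hydrogen in place of nitro on an aromatic carbon, turning 3-nitrophenyl into phenyl: hydrogen in place of nitro on an aromatic carbon.

Going by the values given here, no measured step removes a nitro group directly, so the evidence is indirect. Exchanging pyridin-3-yl for 2-nitrophenyl gave no change at the digits printed from compound 1 to compound 2 (within the scatter), and exchanging it for 3-nitrophenyl gave a 1.1-fold higher number from compound 1 to compound 3 (0.04 log units; within the scatter). Going from 2-nitrophenyl to 3-nitrophenyl gave a 1.1-fold higher number from compound 2 to compound 3 (0.04 log units; within the scatter). None of these changes moved the number in this assay beyond the scatter, and compound 1 reaches 20000 nM with no nitro group at all. A step beyond the scatter is therefore not expected here, and no direction can be favoured.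

The expected step is a 1.1-fold lower number from compound 3 to compound 4 (0.04 log units; within the scatter).

For compound 4 the estimated value is 20000 nM, with an expected range from 11000 nM to 38000 nM.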

Compound 4, half-maximal inhibitory concentration: 17000 nM
Compound 4: middle estimate off by 1.2-fold (0.07 log units), on the high side, and the stated range covers the measured number.
By their numbers in this assay, from the lowest: compounds 4, 1, 2 and 3 (each within the scatter of the next).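

In this assay, going by these compounds alone, taking the nitro group off gave the first direct reading of that change at this place on the ring: a 1.3-fold lower number from compound 3 to compound 4 (0.11 log units; within the scatter), and the same removal from the 2-nitrophenyl group gave a 1.2-fold lower number from compound 2 to compound 4 (0.07 log units; within the scatter), so neither nitro placement shows a measurable contribution beyond the scatter. Within the data shown here, the plain phenyl group also settles a comparison the earlier compounds lacked, since it separates the pyridin-3-yl group from an unsubstituted carbon ring with no nitro group on either, and that exchange gave a 1.2-fold lower number from compound 1 to compound 4 (0.07 log units; within the scatter), so across all four compounds the group on the carbonyl carbon has not moved the number beyond the scatter. Nothing available here accounts for why the four numbers stay so close together.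

The compounds shown leave open whether a group of another kind on the phenyl ring, such as an amine or a carboxylic acid, or a longer chain in place of the ring on the carbonyl carbon, would move the number beyond the scatter. They also leave open whether any change to the shared core itself would do so, since all four compounds carry it unchanged.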